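This account rests on a few compounds, and the source may have more. Where it says the series, first, only, none or still open, it means among the compounds named here.

Of the compounds shown here, two of one shared core have been measured so far. Compound 1 `CC(=O)OCc1ccc2oc(=O)c(C(=O)Oc3cccc(Br)c3)cc2c1` carries a bromophenyl ester, and in a functional assay on HT-1080 cells (Homo sapiens), read by transwell migration, with a stated time of 24 h, tested at 1 uM (on this read-out higher numbers stand for a weaker effect at the one concentration tested and lower numbers for a stronger effect), compound 1 gives 21.8%. Compound 2 `CC(=O)OCc1ccc2oc(=O)c(C(=O)N(C)c3cccc(Cl)c3)cc2c1` carries instead a (3-chlorophenyl)(methyl)amino group on that carbonyl carbon, and in this assay compound 2 gives 82.6%. Going by the values given here, the single step between them, a number 60.8 percentage points higher from compound 1 to compound 2 (beyond the scatter), is the only one available, and it leaves compound 1 as the lower of the two numbers.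

Compound 3 `CCCC(=O)OCc1ccc2oc(=O)c(C(=O)Oc3cccc(Br)c3)cc2c1` keeps the bromophenyl ester of compound 1 untouched and differs from it only at the acetoxy end: ethyl in place of hydrogen on a saturated chain carbon bound to a carbonyl carbon. Among the compounds with values here, the one measured step concerns a different place on the molecule, the carbonyl carbon bearing the aryl group, and says nothing about a lengthening of the acyl chain on the other side. Within the data shown here, there is thus no measured step that bears on this change, and no basis for expecting a step beyond the scatter in either direction.

Compound 3 is therefore expected to stay close to compound 1, with a step of a number 6.2 percentage points higher from compound 1 to compound 3 (within the scatter), giving an estimate of 28% in this assay, within a range from 10% to 55%.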

Compound 3, a percentage reported as activity, at one concentration (the size of the read-out at that concentration, not a potency): 50.5%
Compound 3: the middle estimate sits 22.5 percentage points below what was measured; the range from low to high includes it.
By their numbers in this assay, from the lowest: compound 1; then compound 3; then compound 2.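

The acyl end of the molecule proves not to be a silent place: in this assay, with the bromophenyl ester held fixed, the change from acetoxy to (propylcarbonyl)oxy gives a number 28.7 percentage points higher from compound 1 to compound 3 (beyond the scatter), which on this read-out means a weaker effect at the one concentration tested. Going by these compounds alone, the earlier step, a number 60.8 percentage points higher from compound 1 to compound 2 (beyond the scatter), concerned only the group on the carbonyl carbon bearing the aryl group, so this is the first sign that ethyl in place of hydrogen on a saturated chain carbon bound to a carbonyl carbon also shifts the read-out, though by a smaller step. Nothing available explains why the longer acyl chain has this effect.

From the compounds shown here alone, a single step cannot show how the read-out follows chain length, so what a propanoyl group, a longer chain such as hexanoyl, or a free hydroxyl in place of the acetoxy would do here remains open. Also open, going by these compounds, is whether the same lengthening would have a similar effect when the (3-chlorophenyl)(methyl)amino group of compound 2 stands on the carbonyl carbon.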